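Adding a Hydroxy Group to a Phenyl Side Chain

This account rests on a few compounds, and the source may have more. Where it says the series, first, only, none or still open, it means among the compounds named here.

Compound 1 `COc1cc(OC)cc(C(=O)NC2CCN(Cc3ccc4ccccc4n3)CC2)c1`: 625 nM
Compound 2 `COc1cc(OC)cc(C(=O)NC2CCN(CCCc3ccccc3)CC2)c1`: > 100000 nM

In an assay on isolated protein for binding affinity to melanin-concentrating hormone receptor 1 (Homo sapiens) (on this read-out higher numbers stand for weaker inhibition and lower numbers for stronger inhibition), compound 1 gives 625 nM. For compound 2 the reported > 100000 nM is a limit of this assay, not a number. Going by the values given here, the only measured step, an at least 160-fold higher number from compound 1 to compound 2 (2.20 log units; beyond the scatter), concerns a different change, and the line the limit of > 100000 nM in this assay, at which 1 of the 2 values shown sits, marks where compound 2 stands. Compound 3 `COc1cc(OC)cc(C(=O)NC2CCN(CC[C@H](O)c3ccccc3)CC2)c1` differs from compound 2 by hydroxy in place of hydrogen on a saturated chain carbon bound to an aromatic carbon and a saturated chain carbon. Among the compounds with values here, no measured step addresses a hydroxy group here, so for compound 3 no movement beyond the scatter is expected, a number no higher from compound 2 to compound 3 (the limit leaves the size open). Compound 3 is therefore estimated at 100000 nM, with a range from 20000 nM to 300000 nM.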

Compound 3, inhibition constant: 505 nM
Estimate against measurement, compound 3: 200-fold (2.30 log units) above; the whole stated range lies above it.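

In this assay, this carbon of the side chain proves highly sensitive, since hydroxy in place of hydrogen gives an at least 190-fold lower number from compound 2 to compound 3 (2.29 log units; beyond the scatter). As far as these compounds go, compound 2 has only a limit of the assay, not a number, so the full size of the step stays unknown: the limit of > 100000 nM in this assay, at which 1 of the 3 values shown sits. With the hydroxy group, the phenyl side chain matches the quinolin-2-yl group of compound 1, with a 1.2-fold lower number from compound 1 to compound 3 (0.09 log units; within the scatter).

From the compounds shown here alone, whether an amine or a methoxy group on this carbon would have the same effect remains open. Going by these compounds, the effect of the opposite spatial arrangement of the hydroxy group at this carbon is also open.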